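Iodo for Bromo on a Nucleotide Core

The source may hold more compounds than are shown below. What is called first, only, known or untested is meant among the compounds shown, and "the series" means these compounds.

Compound 1 `O=c1[nH]c(=O)n([C@@H]2O[C@H](COP(=O)(O)O)[C@@H](O)[C@H]2O)cc1Br` was examined in a functional assay on L1210 cells (Mus musculus) (on this read-out lower numbers stand for stronger inhibition and higher numbers for weaker inhibition), where compound 1 gives 376 ug/mL. Its companion compound 2 `O=c1[nH]c(=O)n([C@@H]2O[C@@H]3COP(=O)(O)O[C@H]3[C@H]2O)cc1Br` gives 294 ug/mL in this assay; the two numbers lie within the scatter of repeated measurements, so neither compound can be called the stronger inhibitor, and compound 1 simply carries the higher of the two numbers recorded so far. Among the compounds with values here, no single-point step between these two has been worked out, so nothing further can be drawn from the pair.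

Compound 3 `O=c1[nH]c(=O)n([C@@H]2O[C@H](COP(=O)(O)O)[C@@H](O)[C@H]2O)cc1I` has not yet been measured. Its difference from compound 1 is iodo in place of bromo on an aromatic carbon. Within the data shown here, with no measured step of this kind among the compounds in hand, the expectation rests on the change alone: one halogen exchanged for another on the same aromatic carbon, with nothing altered in ring count, hydrogen-bond donors, acceptors or charge. In this assay the expected step is a 1.3-fold lower number from compound 1 to compound 3 (0.10 log units; within the scatter), a small movement within the scatter rather than a clear shift in either direction. Compound 3 is therefore estimated to give 300 ug/mL in this assay, with a range from 120 ug/mL to 800 ug/mL.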

Compound 3, concentration for 50% inhibition: > 1000 ug/mL
Compound 3 ended at the assay's limit; the forecaster's own chance of this, stated with the estimate: 15%; at least 3.3-fold (0.52 log units) between middle value and limit.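

In this assay compound 3 gives > 1000 ug/mL, which is a limit of the assay and not a number. Within the data shown here, this is the first sign that the aromatic carbon bearing the halogen matters in this read-out, something compound 1 and compound 2 could not show, since both carry bromo there: exchanging bromo for iodo, with no change in rings, hydrogen-bond donors, hydrogen-bond acceptors or net charge, gives an at least 2.6-fold higher number from compound 1 to compound 3 (0.42 log units; beyond the scatter). The step can be stated only as a minimum, and not as an exact size, because compound 3 sits at the limit of the read-out: the limit of > 1000 ug/mL in this assay, at which 1 of the 3 values shown sits.

What the compounds shown leave open is how far compound 3 actually lies from compound 1, and whether the same exchange would give a similar step on the core of compound 2. They also leave open how this position would respond to a group other than the two heavier halogens, such as fluoro, methyl or an amine, so no trend across substituents can yet be drawn from bromo and iodo alone.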